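Compound 3 and Its 1,3-Thiazol-2-yl Counterpart

This account rests on a few compounds, and the source may have more. Where it says the series, first, only, none or still open, it means among the compounds named here.

In a functional assay on KB cells (Homo sapiens) for cytotoxicity (a higher number here means that more compound is needed for the effect, a lower number that less compound is needed), compound 1 (`COC1=C(C)C(=O)/C(=C(O)/C=C/c2ccc(OC)cc2)C(=O)C1(C)C`) gives 2.9 ug/mL, compound 2 (`COC1=C(C)C(=O)/C(=C(O)/C=C/c2ccccc2OC)C(=O)C1(C)C`) gives 2.8 ug/mL and compound 3 (`COC1=C(C)C(=O)/C(=C(O)/C=C/c2c(C)cccc2C)C(=O)C1(C)C`) gives 2.1 ug/mL. Compound 3 thus stands within the scatter of both others. The next structure, compound 4 (`COC1=C(C)C(=O)/C(=C(O)/C=C/c2nccs2)C(=O)C1(C)C`), carries this change: 1,3-thiazol-2-yl in place of 2,6-dimethylphenyl on a double-bonded chain carbon bound to a double-bonded chain carbon. Three measured steps at this same place bear on it: a 1.0-fold lower number from compound 1 to compound 2 (0.02 log units; within the scatter), a 1.4-fold lower number from compound 1 to compound 3 (0.14 log units; within the scatter) and a 1.3-fold lower number from compound 2 to compound 3 (0.12 log units; within the scatter). All three lie within the scatter, but none brings in a five-membered aromatic ring, so they guide this change only loosely. No step beyond the scatter is therefore expected in this assay. The expected step is a 1.3-fold higher number from compound 3 to compound 4 (0.12 log units; within the scatter). The estimate for compound 4 is 2.8 ug/mL, with an expected range from 1.3 ug/mL to 6 ug/mL.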

Compound 4, concentration for half-maximal effect: 3 ug/mL
Estimate against measurement, compound 4: 1.1-fold (0.03 log units) below, and the stated range covers the measured number.
By their numbers in this assay, from the lowest: compounds 3, 2, 1 and 4 (each within the scatter of the next).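

In this assay a five-membered aromatic ring with 2 hetero atoms on a double-bonded chain carbon lies within the scatter of all three compounds with a six-membered aromatic ring (a 1.4-fold higher number from compound 3 to compound 4 (0.15 log units; within the scatter)), (a 1.1-fold higher number from compound 2 to compound 4 (0.03 log units; within the scatter)) and (a 1.0-fold higher number from compound 1 to compound 4 (0.01 log units; within the scatter)). This place therefore accepts 1,3-thiazol-2-yl as well as the three substituted phenyl groups, with no step beyond the scatter. Nothing available accounts for this flat picture.

The compounds shown leave open whether an amine or a carboxylic acid on the aromatic ring would also stay within the scatter. They also leave open whether a longer chain at this place would do so.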